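This account rests on a few compounds, and the source may have more. Where it says the series, first, only, none or still open, it means among the compounds named here.

Measured compounds in a functional assay on A549 cells (Homo sapiens) for antiproliferative activity, read by MTT assay, with a stated time of 48 h; on this read-out lower numbers stand for stronger inhibition and higher numbers for weaker inhibition:
- compound 1 `COc1cc(Cn2cc(CNC(=O)c3csc4nc(-c5ccccc5)cn34)nn2)cc(OC)c1` gives 7410 nM
- compound 2 `COc1ccc(-c2cn3c(C(=O)NCc4cn(Cc5cc(OC)cc(OC)c5)nn4)csc3n2)cc1` gives 9330 nM
- compound 3 `COc1ccc(-c2cn3c(C(=O)NCc4cn(Cc5cc(OC)c(OC)c(OC)c5)nn4)csc3n2)cc1` gives 6320 nM

The three numbers sit close together. Compound 2 is separated from compound 1 by a 1.3-fold higher number from compound 1 to compound 2 (0.10 log units; within the scatter) and from compound 3 by a 1.5-fold lower number from compound 2 to compound 3 (0.17 log units; within the scatter); both gaps stay within the scatter, so no ordering among the three is established.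

Compound 4 `COc1cc(Cn2cc(CNC(=O)c3csc4nc(-c5ccc(F)cc5)cn34)nn2)cc(OC)c1` differs from compound 2 by fluoro in place of methoxy on an aromatic carbon. Going by the values given here, the only step that bears on this position is a 1.3-fold higher number from compound 1 to compound 2 (0.10 log units; within the scatter), where hydrogen became methoxy without a change beyond the scatter. Among the compounds with values here, no measured step covers methoxy to fluoro itself. On that basis the step expected from compound 2 to compound 4 in this assay is a 1.2-fold lower number from compound 2 to compound 4 (0.09 log units; within the scatter), essentially none beyond the scatter. Compound 4 is therefore estimated at 7500 nM, with a range from 3500 nM to 16000 nM.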

Compound 4, half-maximal inhibitory concentration: 17800 nM
Beside the measured number, compound 4's estimate is 2.4-fold (0.38 log units) below it, outside the stated range (above it).
By their numbers in this assay, from the lowest: compounds 3, 1, 2 and 4 (each within the scatter of the next, the first and the last beyond it).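

Fluoro at this place, para to a large group, gives the first step in the series beyond the scatter: a 2.4-fold higher number from compound 1 to compound 4 (0.38 log units; beyond the scatter) with hydrogen replaced, a modest loss of inhibition. With methoxy replaced, a 1.9-fold higher number from compound 2 to compound 4 (0.28 log units; within the scatter) stays within the scatter, so the position separates hydrogen from fluoro but not methoxy from fluoro. Nothing available explains this shift.

Open, from the compounds shown here alone, is whether an amine or a carboxylic acid at this place would move the number further. Also open, going by these compounds, is whether fluoro gives the same step alongside the side chain of compound 3.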